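Swapping the sulfonyl heteroaryl: from imidazole to bromopyridine

The source may hold more compounds than are shown below. What is called first, only, known or untested is meant among the compounds shown, and "the series" means these compounds.

Compound 1 `Cc1noc(C)c1S(=O)(=O)N1CCC(N2CCC(C)CC2)CC1`: in a functional assay on DLD-1 cells (Homo sapiens) for antiproliferative activity, read by CellTiter-Glo, with a stated time of 72 h (on this read-out lower numbers stand for stronger inhibition and higher numbers for weaker inhibition), compound 1 gives > 5000 nM, which is a limit of the assay.
Compound 2 `CC1CCN(C2CCN(S(=O)(=O)c3nccn3C)CC2)CC1`: in this assay compound 2 gives > 5000 nM, which is a limit.
Compound 3 `CC1CCN(C2CCN(S(=O)(=O)c3cn(C)cn3)CC2)CC1`: in this assay compound 3 gives > 5000 nM, again a limit.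

Compound 3 therefore stands at the edge of what this assay can report, and so do both other compounds: the limit of > 5000 nM in this assay, at which 3 of the 3 values shown sit. The three measured steps, a step that the two limits leave unreadable from compound 1 to compound 2, a step that the two limits leave unreadable from compound 1 to compound 3 and a step that the two limits leave unreadable from compound 2 to compound 3, all join two limits and give no readable size, so they show only that changing the aryl group on the sulfonyl sulfur among these three heteroaryls brought nothing inside the measurable range.

Compound 4 `CC1CCN(C2CCN(S(=O)(=O)c3cncc(Br)c3)CC2)CC1` carries one change relative to compound 3: 5-bromopyridin-3-yl in place of 1-methyl-1H-imidazol-4-yl on a sulfonyl sulfur. Within the data shown here, no measured step gives a readable size for such a change, so the expectation is that the step that the limit leaves unreadable from compound 3 to compound 4 stays unreadable, with compound 4 most likely again at the limit. The estimate for compound 4 in this assay is 8000 nM, between 2000 nM and 30000 nM.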

Compound 4, half-maximal inhibitory concentration: > 5000 nM
Compound 4 was reported as a limit; the forecaster's own chance of this, stated with the estimate: 70%; the middle value lies beyond the limit too.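

In this assay compound 4 joins compound 1, compound 2 and compound 3 at the limit, so no step among these four compounds can be read: the limit of > 5000 nM in this assay, at which 4 of the 4 values shown sit. The compounds shown leave open whether any group on the sulfonyl sulfur can bring the shared core inside the measurable range.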